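Cyclohexyl for Phenyl in an Aminothiazole Acylguanidine Agonist

The compounds below may be only part of what the source reports. "The series", "measured", "known", "first", "only" and "open" are said of these compounds alone.

Compound 1: `Cc1nc(N)sc1CCCNC(=N)NC(=O)CC(C)c1ccccc1`, 49 nM
Compound 2: `C[C@@H](CC(=O)NC(=N)NCCCc1c[nH]cn1)c1ccccc1`, 25.1 nM

Of the compounds shown here, two have been tested in a functional assay on cardiac atrium for agonist activity at histamine H2 receptor (Cavia porcellus); on this read-out higher numbers stand for an effect only at larger amounts of compound and lower numbers for an effect already at smaller amounts. Compound 1 gives 49 nM, and compound 2 gives 25.1 nM; the two numbers lie within the scatter of each other, so neither can be called the more potent one on this read-out. Going by the values given here, compound 1 has the higher of the two numbers, with compound 2 as its only neighbour.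

The unmeasured compound 3, `Cc1nc(N)sc1CCCNC(=N)NC(=O)CC(C)C1CCCCC1`, is derived from compound 1 by a single change: cyclohexyl in place of phenyl on a saturated chain carbon bound to two saturated chain carbons. The aminothiazole side, the propyl linker and the acylguanidine are kept unchanged; only the ring on the branched chain carbon is exchanged, one six-membered carbon ring for another of the same size, with no donor or acceptor count altered.

Among the compounds with values here, no measured pair in this set shows the effect of such a ring exchange, so no step can be read from the data. From the two numbers in hand, compound 3 is expected to stay close to compound 1, and the expected step from compound 1 to compound 3 in this assay is a 1.2-fold lower number from compound 1 to compound 3 (0.09 log units; within the scatter), a move not clearly beyond the scatter in either direction. Compound 3 is therefore estimated at 40 nM, with a range from 12 nM to 130 nM.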

Compound 3, half-maximal effective concentration: 69.2 nM
Compound 3: the middle estimate sits 1.7-fold (0.24 log units) below what was measured, and the stated range covers the measured number.
By their numbers in this assay, from the lowest: compounds 2, 1 and 3 (each within the scatter of the next, the first and the last beyond it).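

In this assay, cyclohexyl in place of phenyl on a saturated chain carbon bound to two saturated chain carbons gives a 1.4-fold higher number from compound 1 to compound 3 (0.15 log units; within the scatter), so on this read-out the two compounds cannot be told apart. Going by these compounds alone, this is the first direct look at this position, and it shows that, on the core of compound 1, an aromatic ring at this place is not required for a number of this size, since a non-aromatic ring of carbon only serves within the scatter. Nothing at hand bears on what lies behind this result.

The compounds shown leave open whether this tolerance reaches beyond six-membered rings of carbon only, for instance to a cyclopentyl ring, a pyridine ring, a piperidine ring or an open tert-butyl group at the same place. They also leave open whether the same exchange behaves alike on the core of compound 2, and whether a hydroxyl group or a fluorine atom on the cyclohexyl ring of compound 3 would shift the number beyond the scatter.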